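Fluoro beside the methyl: expected half-life for compound 3

A few compounds are considered here, and "the series" means these few. Any claim that something is new, unique, unknown or untested is made for them only; others in the source may bear on it.

Measured so far in an ADME assay on S9 fraction from liver (Mus musculus) for metabolic stability, read by LC-MS, using NADPH, with a stated time of 60 min, tested at 1 uM; a higher number here means that the compound lasts longer, a lower number that the compound disappears faster:
compound 1 `Cc1ccccc1N(C)C(=O)c1ccc(-c2ccc(OS(N)(=O)=O)cc2)o1` gives 0.417 h
compound 2 `Cc1ccccc1N(C)C(=O)c1ccc(-c2ccc(OS(N)(=O)=O)cc2F)o1` gives 0.383 h

Compound 1 and compound 2 stand within the scatter of each other, as the step of a 1.1-fold lower number from compound 1 to compound 2 (0.04 log units; within the scatter) shows. Compound 3 `Cc1c(F)cccc1N(C)C(=O)c1ccc(-c2ccc(OS(N)(=O)=O)cc2)o1` differs from compound 1 by fluoro in place of hydrogen on an aromatic carbon. Within the data shown here, the one measured step that bears on it, a 1.1-fold lower number from compound 1 to compound 2 (0.04 log units; within the scatter), also concerns fluoro in place of hydrogen on an aromatic carbon, and it stayed within the scatter. No step beyond the scatter is therefore expected in this assay. Compound 3 is expected to give 0.4 h, in the range 0.25 h to 0.65 h, which means an expected step of a 1.0-fold lower number from compound 1 to compound 3 (0.02 log units; within the scatter).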

Compound 3, half-life: 0.08 h
Compound 3: middle estimate off by 5.0-fold (0.70 log units), on the high side; measured number below the stated range.
By their numbers in this assay, from the lowest: compound 3; then compounds 2 and 1 (each within the scatter of the next).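

In this assay, fluoro in place of hydrogen on an aromatic carbon ortho to a methyl group, which gives the 3-fluoro-2-methylphenyl of compound 3, brings a 5.2-fold lower number from compound 1 to compound 3 (0.72 log units; beyond the scatter). The same kind of change at its place in compound 2 gave only a 1.1-fold lower number from compound 1 to compound 2 (0.04 log units; within the scatter), so the outcome of this change depends on where it is made. Nothing available here accounts for the difference between the two places. The compounds shown leave open whether chloro or methoxy on the same aromatic carbon would give a like step, and whether the step is particular to fluoro.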